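Acetyl in place of hydrogen on the ring oxygen

The source may report more compounds than this note shows. Statements on the series, on what has been measured and on what is new or still open speak of the compounds shown alone.

Among the compounds with values here, compound 1 `CCCCCc1nc2c(c(C)c1O)CCN2C` stands lowest of the two numbers so far: in a functional assay on CCRF-CEM cells (Homo sapiens), read by flow cytometry, with stated times of 16 h and 120 min, tested at 1 uM (a lower number here means a weaker effect, a higher number a stronger effect of the compound at the concentration tested), compound 1 gives 40%. Within the data shown here, compound 2 `CCCCCCCCCCc1nc2c(c(C)c1O)CCN2C` gives 80% in this assay, and the only step known so far reads a number 40 percentage points higher from compound 1 to compound 2 (beyond the scatter). Compound 3 `CCCCCc1nc2c(c(C)c1OC(C)=O)CCN2C` differs from compound 1 in one place: acetyl in place of hydrogen on an oxygen on an aromatic ring. Among the measured compounds shown here, that step concerns a chain end and says nothing about the oxygen, so no measured step bears on the change here. Accordingly no step beyond the scatter is expected, no change at the digits printed from compound 1 to compound 3 (within the scatter). For compound 3 the estimate in this assay is 40%, with a range from 20% to 62%.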

Compound 3, a percentage reported as activity, at one concentration (the size of the read-out at that concentration, not a potency): 30%
Compound 3: middle estimate off by 10 percentage points, on the high side, and the stated range covers the measured number.
By their numbers in this assay, from the lowest: compounds 3 and 1 (each within the scatter of the next); then compound 2.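

Acetyl in place of hydrogen on an oxygen on an aromatic ring gives a number 10 percentage points lower from compound 1 to compound 3 (within the scatter) in this assay, the first step read at this oxygen. At this one concentration, the free hydroxy is therefore not shown to be required for the read-out, at least with the pentyl chain. Nothing available explains this result.

Open, as far as these compounds go, is whether a methyl ether or a benzoyl group on this oxygen would read the same. Also open, from the compounds shown here alone, is whether hydroxy to acetoxy on compound 2, at 80%, would again stay within the scatter.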